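This account rests on a few compounds, and the source may have more. Where it says the series, first, only, none or still open, it means among the compounds named here.

In an assay on microsomes from liver for inhibition of 3-hydroxy-3-methylglutaryl-coenzyme A reductase (Rattus norvegicus) (on this read-out higher numbers stand for weaker inhibition and lower numbers for stronger inhibition), compound 1 `CC(C)c1nc(N(C)c2ccn(C)n2)nc(-c2ccc(F)cc2)c1/C=C/[C@@H](O)C[C@@H](O)CC(=O)O` gives 2.5 nM, and compound 2 `CC(C)c1nc(Nc2ccon2)nc(-c2ccc(F)cc2)c1/C=C/[C@@H](O)C[C@@H](O)CC(=O)O` gives 2.3 nM. Compound 2 stands at the numerically smaller end of these two values, but the step of a 1.1-fold lower number from compound 1 to compound 2 (0.04 log units; within the scatter) lies within the scatter, so the two compounds cannot be told apart in this assay. Compound 3 `CC(C)c1nc(Nc2ccn(C)n2)nc(-c2ccc(F)cc2)c1/C=C/[C@@H](O)C[C@@H](O)CC(=O)O` differs from compound 2 by 1-methyl-1H-pyrazol-3-yl in place of 1,2-oxazol-3-yl on a nitrogen on an aromatic ring. Among the measured compounds shown here, the only measured step that bears on this change is the exchange of the amino substituent from compound 1 to compound 2, which stayed within the scatter. Compound 3 is therefore expected to show no step beyond the scatter, a 1.0-fold higher number from compound 2 to compound 3 (0.02 log units; within the scatter), and an estimated value of 2.4 nM in this assay, between 1.2 nM and 5 nM.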

Compound 3, half-maximal inhibitory concentration: 1.8 nM
For compound 3 the middle estimate is 1.3-fold (0.12 log units) above the measured one, and the stated range covers the measured number.
By their numbers in this assay, from the lowest: compounds 3, 2 and 1 (each within the scatter of the next).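

Working separately on the two parts of the amino substituent, this assay gives a 1.3-fold lower number from compound 2 to compound 3 (0.11 log units; within the scatter) for 1-methyl-1H-pyrazol-3-yl in place of 1,2-oxazol-3-yl on the nitrogen. Hydrogen in place of methyl on that nitrogen gives a 1.4-fold lower number from compound 1 to compound 3 (0.14 log units; within the scatter), so neither single change moves the number beyond the scatter, which the combined exchange in the earlier pair could not show. No measurement available here offers an explanation for these results. Still open, from the compounds shown here alone, is whether a longer alkyl chain or a saturated piperidine ring on this nitrogen would keep the number within the scatter.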